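A few compounds are considered here, and "the series" means these few. Any claim that something is new, unique, unknown or untested is made for them only; others in the source may bear on it.

Of the compounds shown here, three built on a shared core have been measured in an ADME assay for permeability, using PAMPA, with a stated time of 4 h; on this read-out higher numbers stand for higher permeability and lower numbers for lower permeability. Compound 1 `Cn1c(COc2cccc(C(=O)O)c2)nc2ccc(Oc3ccc(F)cc3)nc21` gives 8.6 10^-6 cm/s, and compound 2 `Cc1ccc(Oc2cc3c(cn2)nc(COc2cccc(C(=O)O)c2)n3C)cc1` gives 6.8 10^-6 cm/s. Compound 3 `Cn1c(COc2cccc(C(=O)O)c2)nc2ccc(Oc3ccccn3)cc21` gives 2.2 10^-6 cm/s, the lowest of the three numbers; compound 2 sits nearest to it and compound 1 furthest from it, and both of those gaps lie beyond the usual scatter of repeated measurements. Within the data shown here, no two of the measured compounds differ in a single place, so no measured step is available to guide what follows.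

Compound 4 `Cn1c(COc2cccc(C(=O)O)c2)nc2ccc(Oc3cccc(Cl)n3)cc21` has not yet been measured. It differs from compound 3 by chloro in place of hydrogen on an aromatic carbon of the six-membered aromatic ring with one nitrogen, next to the ring nitrogen, with pyridin-2-yl becoming 6-chloropyridin-2-yl. Among the measured compounds shown here, no measured pair shows what such an exchange does in this assay, and the three numbers in hand reveal no pattern tied to that ring. The expected step is a 1.6-fold higher number from compound 3 to compound 4 (0.20 log units; within the scatter), upward and of modest size, which may or may not reach beyond the scatter. Compound 4 is accordingly estimated at 3.5 10^-6 cm/s, within a range from 1.8 10^-6 cm/s to 7 10^-6 cm/s.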

Compound 4, apparent permeability: 7.6 10^-6 cm/s
For compound 4 the middle estimate is 2.2-fold (0.34 log units) below the measured one; measured number outside the range, above it.
By their numbers in this assay, from the lowest: compound 3; then compounds 2, 4 and 1 (each within the scatter of the next).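

In this assay, the exchange of hydrogen for chloro on an aromatic carbon next to the ring nitrogen, which turns pyridin-2-yl into 6-chloropyridin-2-yl, gives a 3.5-fold higher number from compound 3 to compound 4 (0.54 log units; beyond the scatter), the only single-place step among the compounds shown. It shows that this position on the six-membered aromatic ring with one nitrogen is not silent on this read-out: a single added chlorine atom, with no ring, no hydrogen-bond donor or acceptor and no net charge, carries the number beyond the scatter. Nothing at hand explains why the number moves in this way.

Whether this rise belongs to chloro itself or would also follow other groups at this place stays open, since a methyl, a fluoro, a methoxy or an amine on the same carbon is not among the compounds shown. Also open, going by these compounds, is whether chloro would move the number in the same direction on another carbon of that ring, and whether this one step holds anywhere else.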